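Swapping Methyl for Dimethylamino on the Compound 3 Chain

The source may report more compounds than this note shows. Statements on the series, on what has been measured and on what is new or still open speak of the compounds shown alone.

In a functional assay on HT-29 cells (Homo sapiens) for inhibition, with a stated time of 72 h (on this read-out higher numbers stand for weaker inhibition and lower numbers for stronger inhibition), compound 1 (`COc1cc(C(=O)n2ccc3ccccc32)cc(OC)c1OC`) reads 9600 nM and compound 2 (`COc1cc(C(=O)c2cccc3[nH]ccc23)cc(OC)c1OC`) reads 46.4 nM while compound 3 (`CCCn1ccc2cc(C(=O)c3cc(OC)c(OC)c(OC)c3)ccc21`) reads 1800 nM as the middle number of the three, apart from both beyond the scatter. The change (dimethylamino in place of methyl on a saturated chain carbon, two bonds along the chain from an aromatic nitrogen) to compound 4 (`COc1cc(C(=O)c2ccc3c(ccn3CCN(C)C)c2)cc(OC)c1OC`) puts dimethylamino in place of methyl on a saturated chain carbon, two bonds along the chain from an aromatic nitrogen, which turns propyl into 2-(dimethylamino)ethyl. For the measured compounds named here, no measured pair shows this change, so no step beyond the scatter is expected in this assay in either direction. The expected step runs a 1.1-fold higher number from compound 3 to compound 4 (0.05 log units; within the scatter) as an estimate only. Compound 4 is estimated at 2000 nM with a range from 500 nM to 8000 nM expected.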

Compound 4, half-maximal inhibitory concentration: 4600 nM
The estimate for compound 4 lay 2.3-fold (0.36 log units) below the measured number; low and high end bracket the measured number.
By their numbers in this assay, from the lowest: compound 2; then compound 3; then compound 4; then compound 1.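

In this assay the swap of methyl for dimethylamino on a saturated chain carbon, two bonds along the chain from an aromatic nitrogen, gives a 2.6-fold higher number from compound 3 to compound 4 (0.41 log units; beyond the scatter) and so lies beyond the scatter, though the step is modest. This shows that the position is not indifferent to the change, with 2-(dimethylamino)ethyl reading weaker than propyl. No evidence in hand explains the step.

Still open, as far as these compounds go, is how a morpholine, a hydroxyl or a longer chain would read at this position. From the compounds shown here alone, whether the same swap would have a similar effect on another core also remains open.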